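Difluorophenyl in Place of the Sulfonamide Arm

The source may report more compounds than this note shows. Statements on the series, on what has been measured and on what is new or still open speak of the compounds shown alone.

Among the measured compounds shown here, compound 2 `Cc1ccc(S(=O)(=O)NCc2cn(C[C@H](O)[C@H]3OC(=O)C(OCc4ccccc4)=C3OCc3ccccc3)nn2)cc1` is the one member of this set that gives a number in a functional assay on HepG2 cells (Homo sapiens) for antiproliferative activity, read by MTT assay, with a stated time of 72 h; a higher number here means a weaker inhibitor, a lower number a stronger inhibitor: compound 2 gives 24900 nM. Compound 1 `COc1ccc(-c2cn(C/C=C3\OC(=O)C(OCc4ccccc4)=C3OCc3ccccc3)nn2)cc1` is reported in this assay only as a limit, > 100000 nM. Compound 3 `O=C1O/C(=C\Cn2cc(-c3cc(F)cc(F)c3)nn2)C(OCc2ccccc2)=C1OCc1ccccc1` likewise sits at a limit in this assay, > 100000 nM. Because (the limit of > 100000 nM in this assay, at which 2 of the 3 values shown sit), the step from compound 1 to compound 3, a step that the two limits leave unreadable from compound 1 to compound 3, cannot be sized. For the measured compounds named here, compound 2 therefore stands as the only compound with a measured inhibition, the other two resting at the limit.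

Compound 4 `O=C1O[C@H]([C@@H](O)Cn2cc(-c3cc(F)cc(F)c3)nn2)C(OCc2ccccc2)=C1OCc1ccccc1` keeps the core of compound 2 and differs from it in one place: 3,5-difluorophenyl in place of (((4-methylphenyl)sulfonyl)amino)methyl on an aromatic carbon. Going by the values given here, the only measured step, from compound 1 to compound 3, brings in the same 3,5-difluorophenyl group but on the core of compound 3 and cannot be read, so no measured step sizes this change directly. What the two limits show is that the 3,5-difluorophenyl group on the core of compound 3 gave no measurable inhibition. Compound 4 is thus expected to be weaker than compound 2, with an estimated step of a 3.2-fold higher number from compound 2 to compound 4 (0.51 log units; beyond the scatter), and may itself end at the limit. Compound 4 is estimated at 80000 nM, between 20000 nM and 200000 nM.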

Compound 4, half-maximal inhibitory concentration: 11600 nM
Compound 4: middle estimate off by 6.9-fold (0.84 log units), on the high side; the whole stated range lies above it.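

In this assay this position, an aromatic carbon of a five-membered aromatic ring with 3 nitrogen, now carries a change that can be sized, with a 2.1-fold lower number from compound 2 to compound 4 (0.33 log units; beyond the scatter). On the core shared by compound 2 and compound 4, the (((4-methylphenyl)sulfonyl)amino)methyl arm, with its sulfur and its hydrogen-bond donor, is therefore not required for a measured value, and a 3,5-difluorophenyl group holds that place with a modest gain. Compound 3, which bears the same 3,5-difluorophenyl group on its own core, rests at a limit of the assay, so the step to it from compound 1 cannot be read: the limit of > 100000 nM in this assay, at which 2 of the 4 values shown sit.

The compounds shown leave open whether the two fluorines matter on the core of compound 4, since a plain phenyl group or a 4-methoxyphenyl group at this position would be needed to separate them from the aromatic ring itself. They also leave open how this position responds to an amine, a carboxylic acid or a longer alkyl chain in place of 3,5-difluorophenyl.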